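The source may hold more compounds than are shown below. What is called first, only, known or untested is meant among the compounds shown, and "the series" means these compounds.

The set rests on a shared core carrying a methylaminomethyl group and a hydroxyl, as in compound 1 `CNC[C@]1(O)Cc2ccccc2[C@@H]1Oc1ccccc1-c1cccc2ccccc12`. Within the data shown here, in an in vitro assay on HEK293 cells for inhibition of sodium-dependent dopamine transporter (Homo sapiens) (a higher number here means a weaker inhibitor, a lower number a stronger inhibitor), compound 1 gives 10000 nM, and that is the only value in the set that stands as a number. Compound 2 `CNCC1(O)Cc2ccccc2C1Cc1ccccc1C` belongs to the same set. In this assay compound 2 reaches only a limit, > 10000 nM. Among the measured compounds shown here, the weak end of the set is thus marked by the limit of > 10000 nM in this assay, at which 1 of the 2 values shown sits, and compound 1 stands at the one number available, itself a weak one.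

The step of interest runs from compound 1 to compound 3 `CNC[C@]1(O)Cc2ccccc2[C@@H]1Oc1ccccc1F`, which awaits measurement in this assay. The change is fluoro in place of naphthalen-1-yl on an aromatic carbon. For the measured compounds named here, no pair of measured compounds separates the two ends of this change, so no measured step can be pointed to as a guide. Without one, the account expects no step beyond the usual scatter, with at most a slight lean toward a stronger inhibitor. The estimated step is a 2.0-fold lower number from compound 1 to compound 3 (0.30 log units; within the scatter). Compound 3 is therefore expected to give about 5000 nM in this assay, within a plausible range from 1000 nM to 30000 nM.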

Compound 3, half-maximal inhibitory concentration: 4000 nM
For compound 3 the middle estimate is 1.3-fold (0.10 log units) above the measured one; low and high end bracket the measured number.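

At the aromatic carbon ortho to a large group, the first measured change shows a 2.5-fold lower number from compound 1 to compound 3 (0.40 log units; beyond the scatter) in this assay, so both six-membered aromatic rings of naphthalen-1-yl can leave with fluoro in their place and the number still does not rise. Compound 3 gives 4000 nM, which is still a weak value, so this modest step moves the series only slightly and does not lift it out of the weak range. Among these compounds, compound 2 stands at a limit and not at a number, and it differs from compound 1 in more than one place, so it adds no second step, and the weak end of the set stays marked as before: the limit of > 10000 nM in this assay, at which 1 of the 3 values shown sits.

The reading rests on this one pair, which leaves open whether the trend would continue with hydrogen, chloro or methoxy at the same carbon, or would turn back with phenyl, a group of intermediate size. It also leaves open whether the step would hold on a core carrying a primary amine in place of the methylaminomethyl group.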